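This account rests on a few compounds, and the source may have more. Where it says the series, first, only, none or still open, it means among the compounds named here.

Of the compounds shown here, three have been measured so far in a functional assay on HL-60 cells (Homo sapiens) for antiproliferative activity, read by MTT assay; a higher number here means a weaker inhibitor, a lower number a stronger inhibitor. Compound 1, with structure `c1ccc(COC[C@H]2OCC[C@@H](OCc3ccccc3)[C@@H]2OCc2ccccc2)cc1`, gives 39300 nM in this assay. Compound 3, with structure `C=CC[C@@H]1O[C@H](COCc2ccccc2)[C@@H](OCc2ccccc2)[C@H](OCc2ccccc2)[C@H]1OC(C)=O`, gives 26900 nM. Compound 2, with structure `O[C@@H]1[C@@H](OCc2ccccc2)[C@H](OCc2ccccc2)[C@@H](COCc2ccccc2)O[C@H]1CC1CCCCC1`, gives 4100 nM, which is the lowest of the three numbers; its nearest neighbour is compound 3, and the gap to both compound 3 and compound 1 lies beyond the usual scatter, so compound 2 is the strongest inhibitor among the compounds measured here.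

The next compound, compound 4, has structure `CCCC[C@@H]1O[C@H](COCc2ccccc2)[C@@H](OCc2ccccc2)[C@H](OCc2ccccc2)[C@H]1O` and has not yet been measured. It differs from compound 2 in one place: propyl in place of cyclohexyl on a saturated chain carbon bound to a saturated ring carbon. A ring of six carbons is thus replaced by a short open chain of three carbons, while the rest of the structure, including the free hydroxyl group, is kept.

For the measured compounds named here, no step between two measured compounds isolates this kind of change, so the expectation rests on the size of the replaced group alone. The move to a smaller group is expected to cost some activity, giving a step of a 2.2-fold higher number from compound 2 to compound 4 (0.34 log units; beyond the scatter) that is expected to fall somewhat beyond the scatter toward a higher number. Compound 4 is therefore estimated to give 9000 nM in this assay, with a range from 3500 nM to 25000 nM.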

Compound 4, half-maximal inhibitory concentration: "not active" (no number reported)
Compound 4: no number reported, so the estimate cannot be set against anything.
By their numbers in this assay, from the lowest: compound 2; then compounds 3 and 1 (each within the scatter of the next).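

For the compounds shown here, compound 4 is reported as "not active" with no number, so no step from compound 2 to compound 4 can be read. The compounds shown leave open how large the effect of replacing cyclohexyl with propyl is in numbers. Nothing shown offers an explanation for this result.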